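Aryl ketone variation on the boron-containing enone series

The compounds below may be only part of what the source reports. "The series", "measured", "known", "first", "only" and "open" are said of these compounds alone.

Measured so far:
compound 1 `O=C(/C=C/c1ccc2c(c1)B(O)OC2)c1ccc(F)cc1`: 2800 nM
compound 2 `O=C(/C=C/c1ccc2c(c1)B(O)OC2)c1ccc(O)cc1`: 24100 nM
compound 3 `O=C(/C=C/c1ccc2c(c1)B(O)OC2)c1ccccc1F`: 4200 nM

All three share the same enone and the same boron-containing bicyclic part; they differ only in the aryl group on the carbonyl carbon. In a functional assay on HCT-116 cells (Homo sapiens) for cytotoxicity, read by MTT assay, with a stated time of 48 h (on this read-out lower numbers stand for stronger inhibition and higher numbers for weaker inhibition), compound 3 gives 4200 nM, the second highest number of the three. Its nearest neighbour is compound 1 with a 1.5-fold higher number from compound 1 to compound 3 (0.18 log units; within the scatter), a gap that carries no weight. Its furthest is compound 2: a 5.7-fold lower number from compound 2 to compound 3 (0.76 log units; beyond the scatter).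

The next compound, compound 4 `Nc1cccc(C(=O)/C=C/c2ccc3c(c2)B(O)OC3)c1`, is not yet measured. Relative to compound 3 the change is 3-aminophenyl in place of 2-fluorophenyl on a carbonyl carbon.

Going by the values given here, two measured steps bear on it. The step of an 8.6-fold higher number from compound 1 to compound 2 (0.93 log units; beyond the scatter) shows that putting a hydrogen-bond donor and acceptor onto this aryl ring, where none was, raised the number. The step of a 5.7-fold lower number from compound 2 to compound 3 (0.76 log units; beyond the scatter) shows the reverse when the donor-bearing ring is exchanged for a fluorophenyl. Going by these compounds, the move from compound 3 to compound 4 again trades a fluorine-bearing ring for one carrying a donor and acceptor, so a higher number is expected, of roughly the size seen in those steps, though the amino group and its position are untested here.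

For compound 4 the expected value in this assay is 12000 nM (range 4000 nM to 40000 nM), the expected step being a 2.9-fold higher number from compound 3 to compound 4 (0.46 log units; beyond the scatter).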

Compound 4, half-maximal inhibitory concentration: 4500 nM
Beside the measured number, compound 4's estimate is 2.7-fold (0.43 log units) above it; measured number inside the range.
By their numbers in this assay, from the lowest: compounds 1, 3 and 4 (each within the scatter of the next); then compound 2.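

In this assay, the step of a 1.1-fold higher number from compound 3 to compound 4 (0.03 log units; within the scatter) shows that a hydrogen-bond donor and acceptor on the aryl ring at this carbonyl carbon do not by themselves raise the number, and a 1.6-fold higher number from compound 1 to compound 4 (0.21 log units; within the scatter) likewise leaves 3-aminophenyl indistinguishable from 4-fluorophenyl at this position. The step of a 5.4-fold lower number from compound 2 to compound 4 (0.73 log units; beyond the scatter) sets 3-aminophenyl clearly apart from 4-hydroxyphenyl, so among these four compounds, the high number of compound 2 belongs to that particular ring and not to every donor-bearing ring. No accompanying data explain why these two rings part in this assay.

The exchange from compound 2 to compound 4 alters both the substituent and its place on the ring, so the compounds shown cannot tell whether the identity of the group or its ring position separates them. Also open, going by these compounds, is how this position responds to a methoxy group, an amide or a carboxylic acid on the aryl ring, and whether any such ring can bring the number clearly below the cluster formed by compound 1, compound 3 and compound 4.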